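The compounds below may be only part of what the source reports. "The series", "measured", "known", "first", "only" and "open" are said of these compounds alone.

For the measured compounds named here, compound 2 `CCCC(Nc1cncc(-c2ccc(O)c(OCC)c2)n1)c1cccnc1` gives 1000 nM in a functional assay on PC-3 cells (Homo sapiens) for cytotoxicity, read by MTT assay, with a stated time of 72 h (on this read-out higher numbers stand for weaker inhibition and lower numbers for stronger inhibition), the higher of the two numbers measured so far; its nearest neighbour, compound 1 `CCCC(Nc1cncc(-c2ccc(O)c(OC)c2)n1)c1cccnc1`, gives 300 nM in this assay. Going by the values given here, the single measured step, a 3.3-fold higher number from compound 1 to compound 2 (0.52 log units; beyond the scatter), is a modest rise beyond the scatter. Compound 3 `CCCC(Nc1cncc(-c2ccc(O)c(OC(C)C)c2)n1)c1cccnc1` differs from compound 2 by methyl in place of hydrogen on a saturated chain carbon bound to an oxygen on an aromatic ring and a saturated chain carbon. Among the compounds with values here, the only step that bears on this change is the one from compound 1 to compound 2, which placed a methyl on the same chain carbon bound to the aromatic oxygen, so a further rise of similar or somewhat smaller size is expected in this assay for compound 3, though with one step as guide the direction rests on thin evidence. Compound 3 is therefore expected to give about 2000 nM, within 800 nM to 5000 nM, an estimated step of a 2.0-fold higher number from compound 2 to compound 3 (0.30 log units; within the scatter) from compound 2.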

Compound 3, half-maximal inhibitory concentration: 10000 nM
Beside the measured number, compound 3's estimate is 5.0-fold (0.70 log units) below it; the measured number lies above the stated range.
By their numbers in this assay, from the lowest: compound 1; then compound 2; then compound 3.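

Adding a methyl on the saturated chain carbon bound to the aromatic oxygen does not carry a fixed penalty: the step of a 10-fold higher number from compound 2 to compound 3 (1.00 log units; beyond the scatter) in this assay is larger than the step of a 3.3-fold higher number from compound 1 to compound 2 (0.52 log units; beyond the scatter) before it. Taken whole, isopropyl in place of methyl on this oxygen gives a 33-fold higher number from compound 1 to compound 3 (1.52 log units; beyond the scatter) and is the only large step here, so across these three compounds each added carbon has raised the number, and none goes against that order. Nothing at hand explains the size of this step.

Going by these compounds, what stays open is whether the rise follows the branch or simply the added carbon, which an unbranched propyl on the same oxygen would separate. Also open, on these data alone, is whether hydrogen on this oxygen, giving a free hydroxyl, would fall below the number of compound 1.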